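The source may report more compounds than this note shows. Statements on the series, on what has been measured and on what is new or still open speak of the compounds shown alone.

In a functional assay on PC-3 cells (Homo sapiens) for cytotoxicity, read by WST assay, with a stated time of 72 h (on this read-out lower numbers stand for stronger inhibition and higher numbers for weaker inhibition), compound 1 `O=C1Nc2c(ccc(F)c2F)C1(c1ccc(O)cc1)c1ccc(F)cc1` gives 8.6 nM. Compound 2 `CCCOc1ccc(C2(c3ccc(O)cc3)C(=O)Nc3c2ccc(F)c3F)cc1` gives > 1000 nM, which is a limit of the assay and not a number. Compound 3 `CCCCCOc1ccc(C2(c3ccc(O)cc3)C(=O)Nc3c2ccc(F)c3F)cc1` differs from compound 2 by ethyl in place of hydrogen on a saturated chain carbon, three bonds along the chain from an oxygen on an aromatic ring, turning propyl into pentyl. For the measured compounds named here, the only measured step that bears on this is an at least 110-fold higher number from compound 1 to compound 2 (2.06 log units; beyond the scatter), where propoxy stands in place of fluoro on an aromatic carbon. Going by the values given here, that step was large and went towards weaker inhibition, but no step for lengthening the chain has been measured, so no recovery is expected in this assay. The expected result, which stays within the scatter, is a step that the limit leaves unreadable from compound 2 to compound 3. For compound 3 the estimated value is 1500 nM, within an expected range of 500 nM to 5000 nM.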

Compound 3, half-maximal inhibitory concentration: > 1000 nM
Compound 3: no number, only a limit; the forecaster's own chance of this, stated with the estimate: 80%; the middle value is on the limit's open side.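

Pentyloxy in place of fluoro also gives a large loss in this assay, with an at least 110-fold higher number from compound 1 to compound 3 (2.06 log units; beyond the scatter) and so the loss seen with propoxy is not confined to that one chain. Going from propyl to pentyl brings no value back into the readable range. The step between compound 2 and compound 3 cannot be read because both sit at a limit of the assay: the limit of > 1000 nM in this assay, at which 2 of the 3 values shown sit.

On these data alone, how far past that limit either compound lies stays unknown. Also open, as far as these compounds go, is whether methoxy or an amine in place of fluoro would keep the activity of compound 1.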